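The source may report more compounds than this note shows. Statements on the series, on what has been measured and on what is new or still open speak of the compounds shown alone.

Working notes on the series in a toxicity assay on THP-1 cells (Homo sapiens) for cytotoxicity, read by MTT assay, with a stated time of 72 h; on this read-out lower numbers stand for an effect already at smaller amounts and higher numbers for an effect only at larger amounts of compound.

Within the data shown here, compound 3 `Cc1cccc(Cn2cc(/C=N/NC(N)=S)c3ccccc32)c1` is the one compound of the three measured that returns a number rather than a limit: in this assay compound 3 gives 32000 nM. Compound 1 `Cn1c(/C=N/N=C(/N)S)cc2ccccc21` gives in this assay only > 200000 nM, which is a limit of the assay. Compound 2 `Cn1cc(/C=N/NC(N)=S)c2ccccc21` gives in this assay likewise > 200000 nM, again a limit. Among the measured compounds shown here, the one step that can be sized is an at least 6.2-fold lower number from compound 2 to compound 3 (0.79 log units; beyond the scatter), and it is known only as a minimum because of the limit of > 200000 nM in this assay, at which 2 of the 3 values shown sit.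

Compound 4 `NC(=S)N/N=C/c1cn(CCCc2ccccc2)c2ccccc12` differs from compound 3 in one place: phenethyl in place of 3-methylphenyl on a saturated chain carbon bound to an aromatic nitrogen. For the measured compounds named here, no measured step bears directly on this exchange of one aromatic substituent for another at the same place; the step from compound 2 to compound 3 concerns adding such a group where none stood. Both compound 3 and compound 4 carry a six-membered aromatic ring of carbon only on the saturated chain carbon bound to the aromatic nitrogen, so no step beyond the scatter is expected, no change at the digits printed from compound 3 to compound 4 (within the scatter). Compound 4 is therefore estimated at 32000 nM in this assay, within 10000 nM to 110000 nM.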

Compound 4, half-maximal effective concentration: 30000 nM
Compound 4: middle estimate off by 1.1-fold (0.03 log units), on the high side; measured number inside the range.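

In this assay, the saturated chain carbon bound to an aromatic nitrogen takes phenethyl as well as 3-methylphenyl without a separation of the read-out: a 1.1-fold lower number from compound 3 to compound 4 (0.03 log units; within the scatter). A second group carrying one six-membered aromatic ring of carbon only also gives a step beyond the scatter when it stands in place of hydrogen, an at least 6.6-fold lower number from compound 2 to compound 4 (0.82 log units; beyond the scatter), so that step is no longer tied to 3-methylphenyl alone. It is known only as a minimum, for this reason: the limit of > 200000 nM in this assay, at which 2 of the 4 values shown sit.

On these data alone, both groups at this place carry the same kind of ring, so it stays open whether an amine, a carboxylic acid or a saturated chain with no ring would give a number close to those of compound 3 and compound 4. Steps involving compound 1 cannot be read.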